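The source may hold more compounds than are shown below. What is called first, only, known or untested is meant among the compounds shown, and "the series" means these compounds.

Measured compounds:
compound 1 `Cc1cc2c(cc1Cc1ccc(C(=O)NCC3CCCCC3)o1)C(C)(C)CCC2(C)C`, in an assay on isolated protein for binding affinity to Gonadotropin-releasing hormone receptor (Rattus norvegicus) (on this read-out lower numbers stand for stronger inhibition and higher numbers for weaker inhibition), compound 1 gives 1550 nM
compound 2 `Cc1ccc(CNC(=O)c2ccc(Cc3cc4c(cc3C)C(C)(C)CCC4(C)C)o2)cc1`, in this assay compound 2 gives 60 nM

Going by the values given here, compound 2 holds the lowest number of the two; the only other point is compound 1, and the step of a 26-fold lower number from compound 1 to compound 2 (1.41 log units; beyond the scatter) shows how much the aromatic ring gains over the saturated one. Compound 3 `Cc1cc2c(cc1Cc1ccc(C(=O)NCC3CCN(C(=N)N)CC3)o1)C(C)(C)CCC2(C)C` carries a different change at the same place: a group of 9 heavy atoms (6 carbon, 3 nitrogen; one six-membered non-aromatic ring with 1 hetero atom) in place of a group of 7 heavy atoms (7 carbon; one six-membered aromatic ring of carbon only), on a saturated chain carbon bound to an amide-type nitrogen. Among the compounds with values here, only that one step bears on it, and it points toward weaker binding when a saturated ring replaces the aromatic one, so for compound 3 a rise of roughly an 8.3-fold higher number from compound 2 to compound 3 (0.92 log units; beyond the scatter) is expected, though the added nitrogens make the size uncertain. Compound 3 is estimated at 500 nM, within 100 nM to 3000 nM.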

Compound 3, inhibition constant: 2040 nM
Beside the measured number, compound 3's estimate is 4.1-fold (0.61 log units) below it; the measured number falls inside the stated range.
By their numbers in this assay, from the lowest: compound 2; then compounds 1 and 3 (each within the scatter of the next).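

At this place, on a saturated chain carbon bound to an amide-type nitrogen, replacing 4-methylphenyl with the nitrogen-bearing non-aromatic ring costs much binding, a 34-fold higher number from compound 2 to compound 3 (1.53 log units; beyond the scatter), whereas replacing cyclohexyl with it leaves the number within the scatter, a 1.3-fold higher number from compound 1 to compound 3 (0.12 log units; within the scatter). Thus, a non-aromatic ring with or without these added nitrogens gives a far weaker result than the 4-methylphenyl of compound 2. Nothing measured here gives a reason for this pattern. Still open, as far as these compounds go, is whether an amine or a carboxylic acid on the aromatic ring would keep the binding of compound 2.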